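From Pyrimidin-2-yl to 4-Fluorophenyl on an Amide-Type Nitrogen

The source may report more compounds than this note shows. Statements on the series, on what has been measured and on what is new or still open speak of the compounds shown alone.

Cell toxicity can be compared across closely related compounds. In an ADME assay on LLC-MK2 cells (Macaca mulatta) for cytotoxicity, read by spectrophotometry and crystal violet staining, with a stated time of 4 days (on this read-out higher numbers stand for lower toxicity in this test and lower numbers for higher toxicity in this test), compound 1 `CC(C)n1ncc2c(C(=O)Nc3ncccn3)cc(-c3ccsc3)nc21` gives 50000 nM. Its close relative compound 2 `CC(C)n1ncc2c(C(=O)Nc3ncccn3)cc(-c3cccs3)nc21` gives 75000 nM. The step between them, a 1.5-fold higher number from compound 1 to compound 2 (0.18 log units; within the scatter), means the two cannot be told apart. Compound 3 `CC(C)n1ccc2c(C(=O)Nc3ccccn3)cc(-c3cccs3)nc21` gives > 200000 nM, which is a limit of the assay and not a number.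

The next compound, compound 4 `CC(C)n1ncc2c(C(=O)Nc3ccc(F)cc3)cc(-c3ccsc3)nc21`, keeps the core of compound 1 and changes one group: 4-fluorophenyl in place of pyrimidin-2-yl on an amide-type nitrogen. In words, 4-fluorophenyl stands in place of pyrimidin-2-yl on an amide-type nitrogen. Among the measured compounds shown here, the only measured step, a 1.5-fold higher number from compound 1 to compound 2 (0.18 log units; within the scatter), swaps thiophen-3-yl for thiophen-2-yl on an aromatic carbon, so it offers only a weak guide. For the measured compounds named here, no measured step covers a change on the amide-type nitrogen, so the range must stay wide, and no direction can be favoured in this assay. The expected step is a 1.1-fold lower number from compound 1 to compound 4 (0.05 log units; within the scatter), with no shift expected beyond the scatter. For compound 4, the estimated value is 45000 nM, with an expected range from 13000 nM to 150000 nM.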

Compound 4, half-maximal cytotoxic concentration: > 200000 nM
Compound 4: no number, only a limit; the forecaster's own chance of this, stated with the estimate: 20%; middle value at least 4.4-fold (0.64 log units) away from the limit.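

In this assay, among the compounds shown here, where a higher number stands for lower toxicity, putting 4-fluorophenyl in place of pyrimidin-2-yl on the amide-type nitrogen gives an at least 4.0-fold higher number from compound 1 to compound 4 (0.60 log units; beyond the scatter), so this position can shift the read-out, which the thiophene swap, the only earlier step, did not show. Compound 4 gives > 200000 nM, which is a limit of the assay and not a number. The full size of the step therefore cannot be read, and the limit also gives no way to place the compounds that reach it in order: the limit of > 200000 nM in this assay, at which 2 of the 4 values shown sit.

The compounds shown leave open whether the fluorine or the carbon-only ring accounts for the step. A plain phenyl group on the same nitrogen would separate the two, and a 4-methoxyphenyl group would show whether the fluorine can be replaced.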